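The source may hold more compounds than are shown below. What is called first, only, known or untested is meant among the compounds shown, and "the series" means these compounds.

Measured so far in a functional assay on NCI-H460 cells (Homo sapiens) for inhibition, read by sulforhodamine B assay, with a stated time of 48 h; on this read-out higher numbers stand for weaker inhibition of growth and lower numbers for stronger inhibition of growth: compound 1 `Nc1cc(N)c2nc(-c3ccccc3)c(NCc3ccc(Cl)c(Cl)c3)nc2c1` gives 20900 nM; compound 2 `COc1ccc(CNc2nc3cc(N)cc(N)c3nc2-c2ccccc2)cc1OC` gives 24000 nM; compound 3 `Nc1cc(N)c2nc(-c3ccccc3)c(NCc3ccc(F)cc3)nc2c1` gives 4070 nM.

Compound 3 holds the lowest number of the three. Its nearest neighbour is compound 1, and the step between them is a 5.1-fold lower number from compound 1 to compound 3 (0.71 log units; beyond the scatter); the step from compound 2 is a 5.9-fold lower number from compound 2 to compound 3 (0.77 log units; beyond the scatter). Between compound 1 and compound 2 the step is a 1.1-fold higher number from compound 1 to compound 2 (0.06 log units; within the scatter), so the two aryl groups on the benzylamine are not told apart by this assay.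

Compound 4 `Nc1cc(N)c2nc(-c3ccccc3)c(Sc3ccc(Cl)c(Cl)c3)nc2c1` differs from compound 3 in one place: (3,4-dichlorophenyl)sulfanyl in place of (4-fluorobenzyl)amino on an aromatic carbon. Two things change at once. The aryl ring goes back from one fluorine to two chlorines, which in the measured series is the reverse of a 5.1-fold lower number from compound 1 to compound 3 (0.71 log units; beyond the scatter) and so points to a modestly higher number. For the measured compounds named here, the second change, a sulfanyl link in place of the amino group on a saturated chain carbon, has no counterpart among the measured compounds, and its effect cannot be read from them. Taken together, a rise beyond the scatter is expected, of roughly the size seen between compound 3 and compound 1, with wide uncertainty. Compound 4 is therefore estimated at 16000 nM in this assay, within a range of 4000 nM to 60000 nM. That estimate corresponds to an expected step of a 3.9-fold higher number from compound 3 to compound 4 (0.59 log units; beyond the scatter).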

Compound 4, concentration for 50% growth inhibition: 10500 nM
Estimate against measurement, compound 4: 1.5-fold (0.18 log units) above, within the range that was stated.
By their numbers in this assay, from the lowest: compound 3; then compounds 4, 1 and 2 (each within the scatter of the next, the first and the last beyond it).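

At this aromatic carbon, next to the ring nitrogen, a (3,4-dichlorophenyl)sulfanyl group in place of (4-fluorobenzyl)amino gives a 2.6-fold higher number from compound 3 to compound 4 (0.41 log units; beyond the scatter) in this assay, a modest step in which the hydrogen-bond donor count of the group falls from 1 to 0. Compound 4 also lies within the scatter of compound 1, which carries the same dichlorinated ring on its benzylamino link, so with this ring the assay does not tell the two links apart. No measurement shown here explains the step.

What the compounds leave open is how much of the step belongs to the ring and how much to the link, since both changed at once. A (4-fluorophenyl)sulfanyl or a benzylsulfanyl group at this carbon would bear directly on that question.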